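The source may report more compounds than this note shows. Statements on the series, on what has been measured and on what is new or still open speak of the compounds shown alone.

Measured so far:
compound 1 `CCOc1ccc(CCCN2CC=C(CCC(=O)NO)C2=O)cc1` — 3480 nM
compound 2 `Cc1cccc(CCCN2CC=C(CCC(=O)NO)C2=O)c1` — 3480 nM

Of the compounds shown here, two have been tested in a functional assay on PC-3 cells (Homo sapiens) for inhibition, read by sulforhodamine B assay; a higher number here means a weaker inhibitor of growth, a lower number a stronger inhibitor of growth. In that assay compound 1 gives 3480 nM, and compound 2 gives 3480 nM. On these numbers compound 2 stands level with compound 1 at the digits shown; the two values fall within the usual scatter of each other, so no order can be read between them.

The next compound, compound 3 `Cc1ccc(CCCN2CC=C(CCC(=O)NO)C2=O)cc1`, keeps the shared core and differs from compound 2 in one place: 4-methylphenyl in place of 3-methylphenyl on a saturated chain carbon, three bonds along the chain from an amide-type nitrogen in a ring. The two are built from the same atoms, joined differently.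

For the measured compounds named here, since no step between measured compounds is available, the expected size of this change rests on the closeness of compound 1 and compound 2 alone. The step from compound 2 to compound 3 is expected to be a 1.0-fold higher number from compound 2 to compound 3 (0.00 log units; within the scatter), that is, none beyond the scatter. Compound 3 is therefore estimated at 3500 nM, with a range from 1500 nM to 8000 nM.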

Compound 3, concentration for 50% growth inhibition: 3480 nM
For compound 3 the middle estimate is 1.0-fold (0.00 log units) above the measured one; the measured number falls inside the stated range.
By their numbers in this assay, from the lowest: compounds 1, 2 and 3 (each within the scatter of the next).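

In this assay the methyl group can sit as 3-methylphenyl or as 4-methylphenyl with no difference that can be read: the two isomers show no change at the digits printed from compound 2 to compound 3 (within the scatter) and so cannot be ordered. For the compounds shown here, compound 3 also gives the first comparison of two different groups on an aromatic carbon, methyl in place of ethoxy, and this shows no change at the digits printed from compound 1 to compound 3 (within the scatter) even though the two groups differ in size. Nothing given here bears on why these values coincide.

As far as these compounds go, it remains open whether an amine or a carboxylic acid on the aromatic ring, or a longer chain in place of the one carrying that ring, would move the number in this assay at all. Equally open, from the compounds shown here alone, is whether a group such as chlorine on that ring would separate itself from these three compounds.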